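Halogen exchange on the shared core, compound 3 to compound 4

The compounds below may be only part of what the source reports. "The series", "measured", "known", "first", "only" and "open" are said of these compounds alone.

Measured so far in a functional assay on A549 cells (Homo sapiens) for cytotoxicity, read by colorimetric assay and MTT assay, with a stated time of 3 days, tested at 20 uM; on this read-out higher numbers stand for a weaker effect at the one concentration tested and lower numbers for a stronger effect:
- compound 1 `COc1ccc(-c2nc(-c3ccccc3)c(-c3ccc4c(c3)NC(=O)CO4)[nH]2)cc1` gives 38.1%
- compound 2 `O=C1COc2ccc(-c3nn(-c4ccc(Br)cc4)cc3-c3ccccc3)cc2N1` gives 58.8%
- compound 3 `O=C1COc2ccc(-c3nn(-c4ccc(F)cc4)cc3-c3ccccc3)cc2N1` gives 56.4%

Compound 3 sits close to compound 2, the pair separated only by a number 2.4 percentage points lower from compound 2 to compound 3 (within the scatter), while compound 1 lies apart from both, beyond the scatter. Compound 4 `O=C1COc2ccc(-c3nn(-c4ccc(Cl)cc4)cc3-c3ccccc3)cc2N1` is not yet measured; it differs from compound 3 by chloro in place of fluoro on an aromatic carbon. Among the compounds with values here, the only measured step at this position is a number 2.4 percentage points lower from compound 2 to compound 3 (within the scatter), which did not leave the scatter. A chloro group, by size, falls between bromo and fluoro, so no step beyond the scatter is expected here; the estimated step is a number 0.6 percentage points higher from compound 3 to compound 4 (within the scatter). For compound 4 the expected value in this assay is 57%, with a range from 46% to 68%.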

Compound 4, a percentage reported as activity, at one concentration (the size of the read-out at that concentration, not a potency): 52.4%
Compound 4: the middle estimate sits 4.6 percentage points above what was measured; measured number inside the range.
By their numbers in this assay, from the lowest: compound 1; then compounds 4, 3 and 2 (each within the scatter of the next).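

With the chloro compound, three halogens have now been read on this aromatic carbon in this assay, and none of the pairs leaves the scatter: the change gives a number 4 percentage points lower from compound 3 to compound 4 (within the scatter) and, against bromo, a number 6.4 percentage points lower from compound 2 to compound 4 (within the scatter). In these three compounds, the choice among fluoro, chloro and bromo on the 4-halophenyl group therefore does not separate the values. Nothing available explains this flat response.

On these data alone, it remains open whether a non-halogen group at this place, such as an amine or a carboxylic acid, would move the read-out beyond the scatter.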